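Aryl ether series: cytotoxicity limits before compound 4

This account rests on a few compounds, and the source may have more. Where it says the series, first, only, none or still open, it means among the compounds named here.

Compound 1 `CC(C)(C)OC(=O)Nc1ncc(C(Oc2ccc(Br)cc2)c2ccc(Cl)cc2)s1`: in an ADME assay on HepG2 2.2.15 cells (Homo sapiens) for cytotoxicity (on this read-out lower numbers stand for higher toxicity in this test and higher numbers for lower toxicity in this test), compound 1 reaches only the assay limit > 50000 nM.
Compound 2 `CC(C)(C)OC(=O)Nc1ncc(C(Oc2ccc(F)c(Cl)c2)c2ccc(Cl)cc2)s1`: in this assay compound 2 reaches only the assay limit > 50000 nM.
Compound 3 `CC(C)(C)OC(=O)Nc1ncc(C(Oc2cccc(C#N)c2)c2ccc(Cl)cc2)s1`: in this assay compound 3 reaches only the assay limit > 50000 nM.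

Compound 3 therefore stands at the limit and not at a number, and it shares that position with both other compounds, as the limit of > 50000 nM in this assay, at which 3 of the 3 values shown sit, records. The steps a step that the two limits leave unreadable from compound 1 to compound 3 and a step that the two limits leave unreadable from compound 2 to compound 3 have no readable size, and a step that the two limits leave unreadable from compound 1 to compound 2 is in the same position. Compound 4 `Cc1cc(Br)cc(OC(c2ccc(Cl)cc2)c2cnc(NC(=O)OC(C)(C)C)s2)c1` differs from compound 3 by 3-bromo-5-methylphenyl in place of 3-cyanophenyl on an oxygen on a saturated carbon. Each measured step that changes the aryl group on the oxygen stays unreadable, so no direction and no size can be drawn for this assay, and the bare expectation is that compound 4 also ends at the limit. Compound 4 is estimated at 60000 nM, with an expected range from 20000 nM to 200000 nM. The step that the limit leaves unreadable from compound 3 to compound 4 is expected to stay inside the scatter, most likely read only as a limit again.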

Compound 4, half-maximal cytotoxic concentration: > 50000 nM
Compound 4: no number, only a limit; the forecaster's own chance of this, stated with the estimate: 80%; the middle value lies beyond the limit too.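

No step from compound 1, compound 2 or compound 3 to compound 4 can be read in this assay, since all four compounds rest at an assay limit: the limit of > 50000 nM in this assay, at which 4 of the 4 values shown sit.

The compounds shown leave open what size, or direction, any change of the aryl group on the oxygen has on cytotoxicity.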